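A few compounds are considered here, and "the series" means these few. Any claim that something is new, unique, unknown or untested is made for them only; others in the source may bear on it.

Notes on the series.

Four compounds belong here. Compound 1 `C#Cc1nc(/C=C/C(=O)Nc2ccc(Cl)cc2)cs1` and compound 3 `C#Cc1nc(C(=O)Nc2ccc(Cl)cc2)cs1` carry an amide chain on a monocyclic core; compound 2 `Ic1nc2ccccc2s1` and compound 4 `CC#Cc1nc2ccccc2s1` are small fused bicyclic fragments without that chain. The only read-out is a functional assay on HCT-116 cells (Homo sapiens) for cytotoxicity, with a stated time of 3 days; on this read-out lower numbers stand for stronger inhibition and higher numbers for weaker inhibition.

In this assay compound 1 gives 23200 nM. In this assay compound 3 gives 15900 nM. Both sit at the weak end of the scale, and their two values are within the usual scatter of each other, so no order between them is claimed.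

For compound 2 this assay returned only a limit, > 40000 nM, not a number; this is the limit of > 40000 nM in this assay, at which 1 of the 3 values shown sits, so compound 2 stands at the edge of what the assay can report and no closer placing is possible.

Compound 4 differs from compound 2 in one place: prop-1-yn-1-yl in place of iodo on an aromatic carbon. Among the compounds with values here, no measured pair in the set shows what this exchange does. The step of a number no higher from compound 2 to compound 4 (the limit leaves the size open) is expected to be no more than the scatter, with no firm direction, since nothing measured here carries this change. Compound 4 is therefore estimated at 40000 nM, within a range from 15000 nM to 100000 nM, and a further limit rather than a number is quite possible.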

Compound 4, half-maximal inhibitory concentration: > 40000 nM
Compound 4: no number, only a limit (the forecaster's own chance of this, stated with the estimate: 50%); the middle value lies on the limit itself.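

Compound 4, like compound 2, returns only a limit and not a number in this assay: the limit of > 40000 nM in this assay, at which 2 of the 4 values shown sit. Within the data shown here, no step between compound 2 and compound 4 can therefore be read. From the compounds shown here alone, what prop-1-yn-1-yl in place of iodo on an aromatic carbon does in this assay stays open, as does how the two compounds would order beyond that limit.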